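The compounds below may be only part of what the source reports. "The series", "measured", "known", "first", "only" and "open" are said of these compounds alone.

Compound 3 `CC1CCN(c2c(S(=O)(=O)c3ccc(F)cc3)cnc3ccc(Cl)cc23)CC1` is assessed in an assay on isolated protein for displacement of a labelled ligand from metabotropic glutamate receptor 5 (Homo sapiens), with a stated time of 60 min, tested at 1 uM (a lower number here means less inhibition, a higher number more inhibition at the concentration tested (going by the name of the read-out)), where compound 3 gives 89%. Its companions are compound 1 `CC1CCN(c2c(S(=O)(=O)c3cccc(Cl)c3)cnc3ccc(Cl)cc23)CC1`, which gives 92% in this assay, and compound 2 `COc1ccc2ncc(S(=O)(=O)c3ccc(Cl)c(Cl)c3)c(N3CCC(C)CC3)c2c1`, which gives 87%; both numbers lie within the scatter of that of compound 3, so no ranking among the three can be drawn. For the measured compounds named here, the only single-point step among the measured compounds, a number 3 percentage points lower from compound 1 to compound 3 (within the scatter), exchanged the group on the sulfonyl sulfur without moving the number beyond the scatter. Compound 4 `CC1CCN(c2c(S(=O)(=O)c3ccc(Cl)c(Cl)c3)cnc3ccc(Cl)cc23)CC1` has not yet been measured; it differs from compound 3 in one place: 3,4-dichlorophenyl in place of 4-fluorophenyl on a sulfonyl sulfur. Going by the values given here, the same 3,4-dichlorophenyl group on a sulfonyl sulfur occurs in compound 2, which differs from compound 3 elsewhere too, so no single step is available for that pair; its value simply stands close to that of compound 3. Because the step of a number 3 percentage points lower from compound 1 to compound 3 (within the scatter) stayed within the scatter, compound 4 is expected to show a number 1 percentage points higher from compound 3 to compound 4 (within the scatter). The estimate for compound 4 is 90%, with a range from 82% to 96%.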

Compound 4, a percentage reported as inhibition, at one concentration (the size of the read-out at that concentration, not a potency): 86%
For compound 4 the middle estimate is 4 percentage points above the measured one, and the stated range covers the measured number.
By their numbers in this assay, from the lowest: compounds 4, 2, 3 and 1 (each within the scatter of the next).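

In this assay, 3,4-dichlorophenyl in place of 4-fluorophenyl on a sulfonyl sulfur gives a number 3 percentage points lower from compound 3 to compound 4 (within the scatter), so this place accepts a second chlorine-bearing phenyl group with no change beyond the scatter. Chloro in place of hydrogen on an aromatic carbon gives a number 6 percentage points lower from compound 1 to compound 4 (within the scatter), and chloro in place of methoxy on an aromatic carbon gives a number 1 percentage points lower from compound 2 to compound 4 (within the scatter), the first step shown that lies away from the sulfonyl group and likewise stays within the scatter. Nothing available offers an explanation for these small differences.

Going by these compounds, whether a carboxylic acid or an amine on the phenyl ring at the sulfonyl sulfur would move the number beyond the scatter remains open. Inhibition at a single concentration also leaves open how these compounds compare in potency.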